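A smaller heteroaryl ether in place of a quinolinylethyl chain

The source may hold more compounds than are shown below. What is called first, only, known or untested is meant among the compounds shown, and "the series" means these compounds.

Measured compounds:
compound 1 `CC(C)(C)Sc1c(CC(C)(C)C(=O)O)n(Cc2ccc(Cl)cc2)c2ccc(CCc3ccc4ccccc4n3)cc12`: > 3000 nM
compound 2 `CC(C)(C)Sc1c(CC(C)(C)C(=O)O)n(Cc2ccc(Cl)cc2)c2ccc(OCc3ccc4cc(F)ccc4n3)cc12`: 880 nM
compound 3 `CC(C)(C)Sc1c(CC(C)(C)C(=O)O)n(Cc2ccc(Cl)cc2)c2ccc(OCc3cccc(Cl)n3)cc12`: 410 nM

In a functional assay (blood) for inhibition, with Homo sapiens as the target (a lower number here means a stronger inhibitor, a higher number a weaker inhibitor), compound 1 gives only a limit of the assay, not a number. Compound 1 thus stands at the limit of > 3000 nM in this assay, at which 1 of the 3 values shown sits, the weakest point among the values shown. Compound 4 `CC(C)c1csc(COc2ccc3c(c2)c(SC(C)(C)C)c(CC(C)(C)C(=O)O)n3Cc2ccc(Cl)cc2)n1` differs from compound 1 in one place: a group of 10 heavy atoms (7 carbon, 1 nitrogen, 1 oxygen, 1 sulfur; one five-membered aromatic ring with 2 hetero atoms) in place of a group of 12 heavy atoms (11 carbon, 1 nitrogen; one six-membered aromatic ring of carbon only, one six-membered aromatic ring with 1 hetero atom), on an aromatic carbon. Among the compounds with values here, two measured steps bear on this change. The step of an at least 7.3-fold lower number from compound 1 to compound 3 (0.86 log units; beyond the scatter) shows that exchanging the same chain for a smaller group bound through an oxygen lowers the number strongly, and the step of a 2.1-fold lower number from compound 2 to compound 3 (0.33 log units; beyond the scatter) shows that among such oxygen-bound groups a smaller heteroaryl gives a modestly lower number again. A clear drop from compound 1 is therefore expected in this assay. Compound 4 is estimated at 600 nM, between 200 nM and 2000 nM. This estimate corresponds to an expected step of an at least 5.0-fold lower number from compound 1 to compound 4 (0.69 log units; beyond the scatter).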

Compound 4, half-maximal inhibitory concentration: > 3000 nM
Compound 4 gave a limit, no number (the forecaster's own chance of this, stated with the estimate: 10%); middle value at least 5.0-fold (0.69 log units) away from the limit.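

The oxygen-bound link alone does not secure activity in this assay: with the 4-isopropyl-1,3-thiazol-2-yl group there is an at least 7.3-fold higher number from compound 3 to compound 4 (0.86 log units; beyond the scatter), and likewise an at least 3.4-fold higher number from compound 2 to compound 4 (0.53 log units; beyond the scatter). Among these oxygen-bound compounds, the outcome therefore turns on the heteroaryl group at the end of the chain, and smaller is not simply better. Compound 4 gives only a limit of the assay, and its step from compound 1 cannot be read: the limit of > 3000 nM in this assay, at which 2 of the 4 values shown sit.

The compounds shown leave open whether the loss lies with the 1,3-thiazol-2-yl ring or with its isopropyl group. A 1,3-thiazol-2-yl bearing a methyl instead of the isopropyl would separate the two.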